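The source may report more compounds than this note shows. Statements on the series, on what has been measured and on what is new or still open speak of the compounds shown alone.

Measured compounds in an ADME assay on HEK-293T cells (Homo sapiens) for cytotoxicity, read by luminescence, with a stated time of 24 h; on this read-out lower numbers stand for higher toxicity in this test and higher numbers for lower toxicity in this test:
- compound 1 `CCN(CC)C(=O)c1cc2sccc2n1Cc1ccc(OC)cc1`: compound 1 gives > 100000 nM
- compound 2 `CCOC(=O)C1CCN(C(=O)c2cc3sccc3n2Cc2ccc(OC)cc2)CC1`: compound 2 gives 39000 nM

The value for compound 1 is a limit of the assay, not a number. Compound 2 therefore holds the only number shown in this assay; the other entry sits at the limit of > 100000 nM in this assay, at which 1 of the 2 values shown sits. Among the measured compounds shown here, no step between measured compounds is available, so no measured change gives a scale for what follows.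

Compound 3 `COc1ccc(Cn2c(C(=O)N3CCC(C(=O)NCCC(C)C)CC3)cc3sccc32)cc1` is not yet measured in this assay. It differs from compound 2 in one place: isopentylamino in place of ethoxy on a carbonyl carbon. The ester at the end of the ring-bearing chain of compound 2 is thus replaced by an amide bearing the isopentyl chain, with no change to the shared core or to the group on the ring nitrogen.

Without any measured step in the series to draw on, the expectation for compound 3 rests on compound 2 alone. The step from compound 2 to compound 3 is expected to be small, a 1.3-fold lower number from compound 2 to compound 3 (0.11 log units; within the scatter), with no direction beyond the scatter asserted. Compound 3 is estimated at 30000 nM, in the range 10000 nM to 100000 nM, with a fair chance that only a limit is reported.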

Compound 3, half-maximal cytotoxic concentration: 30900 nM
Beside the measured number, compound 3's estimate is 1.0-fold (0.01 log units) below it; the range from low to high includes it.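

In this assay the series now has its first readable step, at a carbonyl carbon whose other neighbour is a saturated ring carbon: a 1.3-fold lower number from compound 2 to compound 3 (0.10 log units; within the scatter). At this place, then, the read-out does not separate the ethoxycarbonyl group from the isopentylcarbamoyl group, even though the entering isopentylamino group has 6 heavy atoms against 3 for ethoxy and brings 1 hydrogen-bond donor where ethoxy has none. Compound 2 and compound 3 both return numbers, so this exchange does not carry the value to the limit of the assay, where only one entry of the set stands: the limit of > 100000 nM in this assay, at which 1 of the 3 values shown sits.

From the compounds shown here alone, whether a carboxylic acid or a small group such as methylamino on the same carbonyl carbon would move the number beyond the scatter remains open, and so does the effect of a cyclic amine there. Going by these compounds, it is also open whether this step stays as small when a group other than the shared one sits on the ring nitrogen.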